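Two-Phenylethenyl in Place of Phenyl: Expecting Compound 3

The compounds below may be only part of what the source reports. "The series", "measured", "known", "first", "only" and "open" are said of these compounds alone.

Measured compounds:
compound 1, `CSc1cnc2ccccc2c1[Se]CC#CCOC(=O)c1ccc(C(=O)O)cc1`, with 3.1 ug/mL in a functional assay on B16 cells (Mus musculus) for antiproliferative activity, with a stated time of 72 h; a higher number here means a weaker inhibitor, a lower number a stronger inhibitor
compound 2, `CSc1cnc2ccccc2c1[Se]CC#CCOC(=O)c1ccccc1`, with 2.1 ug/mL in this assay

For the measured compounds named here, compound 2 stands at the lowest of the two numbers in this assay, but its only neighbour is compound 1, and the step of a 1.5-fold lower number from compound 1 to compound 2 (0.17 log units; within the scatter) is within the scatter, so no order between the two is claimed.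

Compound 3, `CSc1cnc2ccccc2c1[Se]CC#CCOC(=O)/C=C/c1ccccc1`, has not yet been measured. It differs from compound 2 by 2-phenylethenyl in place of phenyl on a carbonyl carbon.

Going by the values given here, only one measured step is known, the exchange of hydrogen for carboxy on an aromatic carbon from compound 1 to compound 2, and it did not reach beyond the scatter. Among the compounds with values here, no measured pair exchanges phenyl for 2-phenylethenyl on a carbonyl carbon, so nothing in the data speaks for a shift in either direction. On that basis a step no larger than the scatter is expected for compound 3, that is a 1.1-fold lower number from compound 2 to compound 3 (0.02 log units; within the scatter).

Compound 3 is therefore estimated at 2 ug/mL in this assay, with a range from 0.9 ug/mL to 4.5 ug/mL.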

Compound 3, concentration for 50% inhibition: 3.1 ug/mL
The estimate for compound 3 lay 1.6-fold (0.19 log units) below the measured number, within the range that was stated.
By their numbers in this assay, from the lowest: compounds 2, 1 and 3 (each within the scatter of the next).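

In this assay, 2-phenylethenyl in place of phenyl on the carbonyl carbon, which adds a double bond outside aromatic rings to the group, gives a 1.5-fold higher number from compound 2 to compound 3 (0.17 log units; within the scatter) and so shows that this larger group can stand at this position with no step beyond the scatter. The exchange at the same place of 4-carboxyphenyl for 2-phenylethenyl gives no change at the digits printed from compound 1 to compound 3 (within the scatter) and extends the picture: the three groups on this carbonyl carbon now all lie within the scatter of one another, and none of them separates from the rest in this assay. Nothing available bears on why these three groups read alike.

As far as these compounds go, what remains open is whether a group of another kind on this carbonyl carbon, such as an aminoalkyl chain or a plain methyl, would produce a step beyond the scatter, and whether the double bond matters at all, which the saturated 2-phenylethyl group could show. The compounds shown also leave open how the number responds to any change elsewhere, since the shared core and the butynyl link stay the same throughout.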